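The source may hold more compounds than are shown below. What is called first, only, known or untested is meant among the compounds shown, and "the series" means these compounds.

Working notes on the series. In a functional assay on T98G cells (Homo sapiens) for inhibition, read by colorimetric assay and MTT assay, with a stated time of 72 h (on this read-out higher numbers stand for weaker inhibition and lower numbers for stronger inhibition), compound 1 (`C=CCCCCOc1ccccc1-c1cnc(OCCC=C)n1C`) gives 29000 nM as the lowest of the two numbers, and compound 2 (`C=CCCCCOc1ccc(C)cc1-c1cnc(OCCC=C)n1C`) gives 94000 nM as the other. Compound 3 (`C=CCCCCOc1cc(F)ccc1-c1cnc(OCCC=C)n1C`) reaches only a limit (> 100000 nM).

Compound 4 (`C=CCCOc1ncc(-c2ccccc2OC)n1C`) is not yet measured and differs from compound 1 in the ether chain (hydrogen in place of pent-4-en-1-yl on a saturated chain carbon bound to an oxygen on an aromatic ring). The change is hydrogen in place of pent-4-en-1-yl on a saturated chain carbon bound to an oxygen on an aromatic ring, which also reads as (hex-5-en-1-yl)oxy to methoxy.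

Within the data shown here, no measured step touches this chain, so the two available steps bear on it only indirectly. Methyl in place of hydrogen on an aromatic carbon gave a 3.2-fold higher number from compound 1 to compound 2 (0.51 log units; beyond the scatter) in a modest move. The added fluoro group gave an at least 3.4-fold higher number from compound 1 to compound 3 (0.53 log units; beyond the scatter) in a move that is at least modest. Both changes to compound 1 therefore moved this assay toward weaker inhibition, and a step of similar size in the same direction is expected here, although the site is different.

The expected move is a 2.2-fold higher number from compound 1 to compound 4 (0.35 log units; beyond the scatter) as an estimate. For compound 4 the estimated value is 65000 nM with an expected range of 22000 nM to 150000 nM in this read-out.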

Compound 4, half-maximal inhibitory concentration: 39000 nM
Beside the measured number, compound 4's estimate is 1.7-fold (0.22 log units) above it, and the stated range covers the measured number.
By their numbers in this assay, from the lowest: compounds 1 and 4 (each within the scatter of the next); then compound 2. At a limit, above all of these: compound 3.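

In this assay, among these compounds, hydrogen in place of pent-4-en-1-yl, which reads as (hex-5-en-1-yl)oxy to methoxy, gives a 1.3-fold higher number from compound 1 to compound 4 (0.13 log units; within the scatter), so at this place removing the 5 heavy atoms and the double bond outside aromatic rings leaves no step that can be told from the scatter. Among the compounds shown here, this is the first change on a saturated chain carbon bound to an oxygen on an aromatic ring, and its reading differs from those of the methyl and fluoro changes on aromatic carbons, both of which are printed as beyond the scatter. Nothing shown here bears on why the chain can be cut back this far with a step that stays within the scatter.

The compounds shown leave open whether a chain longer than hex-5-en-1-yl, or an amine or a carboxylic acid carried at the end of this chain, would give a step beyond the scatter. They also leave open whether the methyl and fluoro changes would give steps of similar size when made on compound 4.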